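A few compounds are considered here, and "the series" means these few. Any claim that something is new, unique, unknown or untested is made for them only; others in the source may bear on it.

Measured compounds:
- Compound 1 `CC(C)=C1CC[C@]2(C)CC[C@]3(O[C@H](C[C@@H]3C)C[C@]3(C)O[C@H]3C1=O)O2`: in a functional assay on NCI-H292 cells (Homo sapiens) for cytotoxicity, read by MTT assay, with a stated time of 24 h (on this read-out lower numbers stand for stronger inhibition and higher numbers for weaker inhibition), compound 1 gives > 50000 nM, a limit of the assay rather than a number.
- Compound 2 `CC(=O)O[C@@]1(C)CCC(=O)[C@@H](C)CCC[C@]2(C)O[C@H]2C(=O)C(=C(C)C)CC1`: in this assay compound 2 gives 21400 nM.
- Compound 3 `CC(=O)O[C@]1(C)CCC(=C(C)C)C(=O)[C@@H]2O[C@@]2(C)C[C@H]2C[C@H](C)[C@@](O)(CC1)O2`: in this assay compound 3 gives > 50000 nM, again a limit and not a number.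

Compound 1 therefore stands at the ceiling of what this assay reports, and it does not stand there alone, because of the limit of > 50000 nM in this assay, at which 2 of the 3 values shown sit. Of the three compounds shown, only compound 2 returns a number, and nothing connects compound 2 or compound 3 to compound 1 by a single change, so no measured step is available to calibrate how a small alteration moves the read-out.

Compound 4 `CC(C)=C1CC[C@]2(C)CC[C@]3(O[C@H](C[C@H]3C)C[C@]3(C)O[C@H]3C1=O)O2` is the next compound to be tested. It keeps every atom and bond of compound 1: the two compounds have the same atoms and bonds and differ only in configuration as drawn: 1 of 6 stereo elements differ; a stereocentre at a saturated ring carbon is drawn S in compound 1 and R in compound 4. Since compound 1 is itself only known as a limit, and a single inversion at a saturated ring carbon is the whole difference, no step beyond the scatter is expected in this assay in either direction; the most likely outcome is that compound 4 again returns only a limit.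

For compound 4 the expected value is 60000 nM, with a range from 20000 nM to 200000 nM, which amounts to an estimated step that the limit leaves unreadable from compound 1 to compound 4.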

Compound 4, half-maximal inhibitory concentration: 48100 nM
Estimate against measurement, compound 4: 1.2-fold (0.10 log units) above; the measured number falls inside the stated range.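

Inverting the single stereocentre at a saturated ring carbon, from S to R, gives in this assay an at least 1.0-fold lower number from compound 1 to compound 4 (0.01 log units; that floor lies within the scatter). This is the first pair among the compounds shown that is joined by one change, and it isolates configuration at this position from every other feature of the structure: the fact that compounds 1 and 4 differ only in the configuration as drawn. Compound 1 remains a limit, so the step has a floor but no upper end, and the pair cannot show how far this inversion really moves the read-out: the limit of > 50000 nM in this assay, at which 2 of the 4 values shown sit.

The compounds shown leave open whether inversion at any of the other stereo elements would give a step beyond the scatter, since this position is the only one tested on its own. They also leave open whether a group added to the shared core, such as an amine or a carboxylic acid, would bring the number in this assay well away from this limit, in either configuration at the saturated ring carbon.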